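The source may report more compounds than this note shows. Statements on the series, on what has been measured and on what is new or still open speak of the compounds shown alone.

Measured in a functional assay on SK-N-SH cells (Homo sapiens) for cytotoxicity, read by MTT assay, with a stated time of 48 h; a higher number here means a weaker inhibitor, a lower number a stronger inhibitor
compound 1 `C=C(c1ccc(OC)cc1)c1cc(OC)c(OC)c(OC)c1-c1ccccc1` gives 31000 nM
compound 2 `C=C(c1ccc(OC)cc1)c1cc(OC)c(OC)c(OC)c1-c1ccc(Cl)cc1` gives 15000 nM

Compound 1 holds the higher of the two numbers. Compound 3 `C=C(c1ccc(C(F)(F)F)cc1)c1cc(OC)c(OC)c(OC)c1-c1ccccc1` keeps the core of compound 1 and carries one change (trifluoromethyl in place of methoxy on an aromatic carbon), trifluoromethyl in place of methoxy on an aromatic carbon. For the measured compounds named here, the only measured step (a 2.1-fold lower number from compound 1 to compound 2 (0.32 log units; beyond the scatter)) is modest and puts chloro in place of hydrogen, so it bears only loosely on this change. The estimated step (a 1.6-fold lower number from compound 1 to compound 3 (0.19 log units; within the scatter)) is of similar modest size toward a lower number in this assay, though none beyond the scatter is also possible. For compound 3 the expected value is 20000 nM (estimated range 8000 nM to 50000 nM) for now.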

Compound 3, half-maximal inhibitory concentration: 13000 nM
Compound 3: the middle estimate sits 1.5-fold (0.19 log units) above what was measured, within the range that was stated.
By their numbers in this assay, from the lowest: compounds 3 and 2 (each within the scatter of the next); then compound 1.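

In this assay, trifluoromethyl in place of methoxy gives a 2.4-fold lower number from compound 1 to compound 3 (0.38 log units; beyond the scatter), so the methoxy is not required at this position for the activity of compound 1. For the compounds shown here, this is the first reading at this position, as the earlier chloro step lay elsewhere on the core, and the modest step shows that a hydrogen-bond acceptor can leave here without loss. No available evidence accounts for the step. As far as these compounds go, how an amine or a carboxylic acid at this position would read remains open. Also open, from the compounds shown here alone, is whether the chloro and trifluoromethyl changes add up when combined.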